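The compounds below may be only part of what the source reports. "The series", "measured", "known", "first", "only" and "open" are said of these compounds alone.

Measured compounds:
- Compound 1 `C=C1C[C@]23C[C@@]1(O)CC[C@H]2c1ccc(OS(=O)(=O)c2ccc(C)cc2)c(C)c1[C@@H]3Cn1cc(-c2ccc(Cl)cc2)nn1`: in a functional assay on SW480 cells (Homo sapiens) for cytotoxicity, read by MTT assay, with a stated time of 4 days (on this read-out lower numbers stand for stronger inhibition and higher numbers for weaker inhibition), compound 1 gives > 20000 nM, which is a limit of the assay and not a number.
- Compound 2 `C=C1C(=O)[C@]23C[C@@]1(O)CC[C@H]2c1ccc(OS(=O)(=O)c2ccc(C)cc2)c(C)c1[C@@H]3Cn1cc(-c2ccc(Br)cc2)nn1`: in this assay compound 2 gives 1590 nM.

Compound 1 thus stands at the edge of what this assay can report: its value is a limit, and of the two values shown it is the one that sits there, as noted in the limit of > 20000 nM in this assay, at which 1 of the 2 values shown sits. Going by the values given here, compound 2 differs from compound 1 in more than one place, so its value only shows that a measurable number is reachable; no single step between measured compounds is available here.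

The unmeasured compound is compound 3 `C=C1C[C@]23C[C@@]1(O)CC[C@H]2c1ccc(OS(=O)(=O)c2ccc(C)cc2)c(C)c1[C@@H]3Cn1cc(-c2ccc(Br)cc2)nn1`. It differs from compound 1 only by bromo in place of chloro on an aromatic carbon. Among the compounds with values here, an exchange of one halogen for another of this kind is a small change, and no measured step is available to suggest otherwise, so the expected step that the limit leaves unreadable from compound 1 to compound 3 is none beyond the usual scatter. Compound 3 is therefore estimated at 25000 nM, within a range from 8000 nM to 80000 nM, with a fair chance that this assay again reports only a limit.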

Compound 3, half-maximal inhibitory concentration: > 20000 nM
Compound 3 ended at the assay's limit; the forecaster's own chance of this, stated with the estimate: 70%; the middle value does not contradict the limit.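

In this assay, compound 1 and compound 3 both end at a limit of the assay and not at a number, so no step can be read for bromo in place of chloro: the limit of > 20000 nM in this assay, at which 2 of the 3 values shown sit.

The compounds shown leave open whether the carbonyl in the core accounts for the gap between compound 3 and compound 2, which gives 1590 nM.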